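The source may report more compounds than this note shows. Statements on the series, on what has been measured and on what is new or still open speak of the compounds shown alone.

Of the compounds shown here, two share one core and have been tested in a functional assay on the whole organism (strain Jcl:SD) for inhibition, with Rattus norvegicus as the target, with stated times of 3 min and 3 h, at a dose of 1 mg/kg by the intravenous route; a lower number here means less inhibition, a higher number more inhibition at the dose given (going by the name of the read-out). Compound 1 `CNCc1cc(-c2ccccc2C(F)(F)F)n(S(=O)(=O)c2ccc(C)cc2)c1` gives 86% in this assay. Compound 2 `CNCc1cc(-c2cccnc2F)n(S(=O)(=O)c2cccc(OC)c2)c1` gives 92% in this assay, a number that sits alongside that of compound 1, the gap between them lying within the scatter. Compound 3 `CNCc1cc(-c2cccnc2F)n(S(=O)(=O)c2cccnc2)c1` is the next compound, and it differs from compound 2 by pyridin-3-yl in place of 3-methoxyphenyl on a sulfonyl sulfur. Among the compounds with values here, no step of this kind has been measured here, so the expected step from compound 2 to compound 3 is a number 7 percentage points lower from compound 2 to compound 3 (within the scatter), small and within the scatter. Compound 3 is therefore estimated to give 85% in this assay, within a range from 65% to 95%.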

Compound 3, a percentage reported as inhibition, in the whole organism at one dose (the size of the read-out at that dose, not a potency): 96%
Estimate against measurement, compound 3: 11 percentage points below, outside the stated range (above it).
By their numbers in this assay, from the lowest: compounds 1, 2 and 3 (each within the scatter of the next).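

In this assay, pyridin-3-yl in place of 3-methoxyphenyl on a sulfonyl sulfur gives a number 4 percentage points higher from compound 2 to compound 3 (within the scatter) at the single dose used. At this position, then, a ring with 1 hetero atom reads the same as a ring of carbon only, and the read-out does not separate the two groups. Going by these compounds, whether a non-aromatic group such as cyclohexyl, or a ring carrying a carboxylic acid or an amine, would hold the read-out on the same sulfur stays open. Nothing available explains why these two groups read alike.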